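Piperidine attachment point in a ubiquitin hydrolase 7 series

The source may report more compounds than this note shows. Statements on the series, on what has been measured and on what is new or still open speak of the compounds shown alone.

Measured compounds and values:
- compound 1, `Cc1cc(Cl)cc(-c2ccnc3cc(CN4C(=O)CCC4=O)sc23)c1O[C@H]1CCCNC1`, 180 nM
- compound 2, `Cc1cc(Cl)cc(-c2ccnc3cc(CN4C(=O)C5CC5C4=O)sc23)c1C[C@@H]1CNCCO1`, 35 nM
- compound 3, `Cc1cc(Cl)cc(-c2ccnc3cc(CN4C(=O)C5C(C4=O)C5(C)C)sc23)c1OC1CCCNC1`, 250 nM

All three were run in an assay on RKO cells for inhibition of ubiquitin carboxyl-terminal hydrolase 7 (Homo sapiens), read by a luciferase reporter, with a stated time of 18 h; on this read-out higher numbers stand for an effect only at larger amounts of compound and lower numbers for an effect already at smaller amounts. Compound 1 sits close to compound 3: the two values lie within the usual scatter of the read-out, so no order can be drawn between them. Compound 2 gives a lower number than compound 1, and that gap lies beyond the scatter; compound 2 carries a different linker and a different ring on the core, so the difference is not traced to a single change.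

Compound 4, `Cc1cc(Cl)cc(-c2ccnc3cc(CN4C(=O)CCC4=O)sc23)c1OC1CCNCC1`, is the next compound to be measured in this assay. It differs from compound 1 only in the attachment point of the saturated ring: piperidin-4-yl in place of piperidin-3-yl on an oxygen on an aromatic ring. Within the data shown here, no pair of measured compounds shows this kind of change, so there is no measured step to lean on. Both variants keep the same donor and acceptor count, and compound 3, which carries the piperidin-3-yl group without a defined stereocentre, gives a number within the scatter of compound 1. The expectation is therefore a small step toward higher numbers, at most at the edge of the scatter, as a 1.7-fold higher number from compound 1 to compound 4 (0.22 log units; within the scatter). Compound 4 is expected at 300 nM, within a range from 100 nM to 900 nM.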

Compound 4, half-maximal effective concentration: 400 nM
Beside the measured number, compound 4's estimate is 1.3-fold (0.12 log units) below it, within the range that was stated.
By their numbers in this assay, from the lowest: compound 2; then compounds 1, 3 and 4 (each within the scatter of the next, the first and the last beyond it).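

Piperidin-4-yl in place of piperidin-3-yl on an oxygen on an aromatic ring gives the first step in this series that changes one place only, and in this assay it reads as a 2.2-fold higher number from compound 1 to compound 4 (0.35 log units; beyond the scatter), a modest shift that shows this part of the molecule responds to where the saturated ring is attached. Heavy atoms, hydrogen-bond donor and acceptor counts, and net charge are the same on both sides, so the counted features of the group do not separate the two compounds, but the defined stereocentre of piperidin-3-yl leaves with the change, and this single step cannot divide the effect of the attachment point from the loss of that stereocentre. Nothing measured here bears on why the attachment point shifts the number.

On these data alone, it remains open how the opposite stereoisomer of the piperidin-3-yl group would read, and whether a smaller ring such as pyrrolidin-3-yl or azetidin-3-yl on the same oxygen would follow the same direction. As far as these compounds go, it is also open whether piperidin-4-yl would give a step of similar size on the other ring systems attached to the shared core, such as that of compound 2.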